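A few compounds are considered here, and "the series" means these few. Any claim that something is new, unique, unknown or untested is made for them only; others in the source may bear on it.

Working notes on the series. Compound 1 `CN(C)CCCNc1nc(NCc2ccco2)c2ccccc2n1` carries a chain that ends in a dimethylamino group on the shared core; in a functional assay on DU-145 cells (Homo sapiens) for cytotoxicity, read by MTT assay, with a stated time of 2 days, tested at 10 uM (a lower number here means less inhibition, a higher number more inhibition at the concentration tested (going by the name of the read-out)), compound 1 is recorded as "not determined" (no result reported), so it stands nowhere on the numbers here. Among the compounds with values here, the only measured member of the set, compound 2 `CCCCNc1nc(NCc2ccco2)c2cc(F)ccc2n1`, in this assay gives 75.4%. Compound 3 `CN(C)CCNc1nc(NCc2ccco2)c2ccccc2n1` differs from compound 1 by dimethylamino in place of (dimethylamino)methyl on a saturated chain carbon, two bonds along the chain from a nitrogen on an aromatic ring, that is, a shorter chain between the ring nitrogen and the terminal dimethylamino group. Within the data shown here, no measured step for this change exists among the compounds here, and compound 1 itself lacks a number, so the size and direction of the step cannot be read from the data; the expectation is a step not beyond the scatter in this assay. Going by compound 2, compound 3 is estimated in this assay at 62%, with a range of 35% to 88%.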

Compound 3, a percentage reported as inhibition, at one concentration (the size of the read-out at that concentration, not a potency): 20%
For compound 3 the middle estimate is 42 percentage points above the measured one, outside the stated range (below it).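

No step can be read between compound 1 and compound 3 in this assay on the values shown. The compounds shown leave open how 2-(dimethylamino)ethyl and 3-(dimethylamino)propyl compare on the shared core in this assay here. No evidence bears on this result.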